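A few compounds are considered here, and "the series" means these few. Any claim that something is new, unique, unknown or untested is made for them only; others in the source may bear on it.

In an ADME assay on MDCK cells (Canis lupus familiaris) for cytotoxicity, read by MTT assay, with a stated time of 24 h (on this read-out lower numbers stand for higher toxicity in this test and higher numbers for lower toxicity in this test), compound 1 `c1ccc(N2CCN=C2c2ccc(C3=NCCN3c3ccccc3)cc2)cc1` gives > 817000 nM as a limit of the assay. Compound 3 `c1cncc(N2CCN=C2c2ccc(C3=NCCN3c3cccnc3)cc2)c1` gives > 813000 nM as a limit too. Going by the values given here, compound 2 `Fc1ccc(N2CCN=C2c2ccc(C3=NCCN3c3ccc(F)cc3)cc2)cc1` at 144000 nM holds the only actual number among the three. Compound 4 `Fc1ccc(N2CCN=C2c2ccc(C3=NCCN3)cc2)cc1` differs from compound 2 by hydrogen in place of 4-fluorophenyl on an amine nitrogen in a ring with hydrogen in place of 4-fluorophenyl on an amine nitrogen in a ring. Among the compounds with values here, no measured pair shows this change alone. Compound 2 at 144000 nM shares a 4-fluorophenyl with compound 4, so only a modest move to a higher number is expected. The expected change is a 1.7-fold higher number from compound 2 to compound 4 (0.24 log units; within the scatter) toward lower toxicity. Compound 4 is estimated at 250000 nM with an expected range of 80000 nM to 800000 nM for this read-out.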

Compound 4, half-maximal cytotoxic concentration: > 971000 nM
Compound 4: no number, only a limit; the forecaster's own chance of this, stated with the estimate: 35%; at least 3.8-fold (0.58 log units) between middle value and limit.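

In this assay, hydrogen in place of 4-fluorophenyl on an amine nitrogen in a ring gives an at least 6.7-fold higher number from compound 2 to compound 4 (0.82 log units; beyond the scatter). Going by these compounds alone, this is the first single-place step, and it shows that one 4-fluorophenyl at this position can go with a step beyond the scatter. From the compounds shown here alone, compound 4 gives only a limit, so the full size of the step stays unknown: the limit of > 971000 nM in this assay, at which 1 of the 4 values shown sits.

Open, going by these compounds, is where a methyl or an acetyl on this ring nitrogen would fall. Also open, on these data alone, is whether the same change behaves alike on the core of compound 1 or compound 3.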